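This account rests on a few compounds, and the source may have more. Where it says the series, first, only, none or still open, it means among the compounds named here.

Working notes on the series

Compound 1 `Cc1cccc(NNC(=O)c2ccc(NS(=O)(=O)c3cnc(O)nc3O)cc2)c1` and compound 2 `O=C(NNc1ccccc1Cl)c1ccc(NS(=O)(=O)c2cnc(O)nc2O)cc1` share one core; compound 3 `Cc1cccc(NNC(=O)c2cccc(NS(=O)(=O)c3cnc(O)nc3O)c2)c1` and compound 4 `O=C(NNc1ccccc1Cl)c1cccc(NS(=O)(=O)c2cnc(O)nc2O)c1` share another. Compound 3 has the same atoms as compound 1, joined differently, and the difference between the two cores is not broken down here.

In a functional assay on A549 cells (Homo sapiens) for antiproliferative activity, read by MTT assay, with a stated time of 24 h (a lower number here means a stronger inhibitor, a higher number a weaker inhibitor), compound 1 gives > 20000 nM, which is a limit of the assay and not a number. In this assay compound 2 gives 3340 nM. The change between them is 2-chlorophenyl in place of 3-methylphenyl on an amine nitrogen, and it produces an at least 5.9-fold lower number from compound 1 to compound 2 (0.77 log units; beyond the scatter). Because the limit of > 20000 nM in this assay, at which 2 of the 3 values shown sit, is where the value of compound 1 sits, only the floor of that step is known; its true size may be larger.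

In this assay compound 3 gives > 20000 nM, again a limit and not a number. The change from compound 3 to compound 4 is 2-chlorophenyl in place of 3-methylphenyl on an amine nitrogen, the same change as before, now on the other core. Whether it carries the same gain is open: the starting point is a limit, so compound 3 may sit well above it, and the core of compound 3 has no other reading. Still, the step of an at least 2.5-fold lower number from compound 3 to compound 4 (0.39 log units; beyond the scatter) is expected, resting on what compound 1 and compound 2 showed in an at least 5.9-fold lower number from compound 1 to compound 2 (0.77 log units; beyond the scatter). For compound 4 the estimate is 8000 nM, with a range from 2500 nM to 30000 nM.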

Compound 4, half-maximal inhibitory concentration: 1460 nM
Beside the measured number, compound 4's estimate is 5.5-fold (0.74 log units) above it, outside the stated range (below it).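

In this assay the replacement of 3-methylphenyl by 2-chlorophenyl on an amine nitrogen also carries over to the core of compound 3, with an at least 13-fold lower number from compound 3 to compound 4 (1.13 log units; beyond the scatter). In these two pairs, the only ones shown, the change therefore goes with a lower number on both cores, and the step on each core lies beyond the scatter: the same change on two cores in this assay, an at least 5.9-fold lower number (0.77 log units; beyond the scatter) from compound 1 to compound 2 and an at least 13-fold lower number (1.13 log units; beyond the scatter) from compound 3 to compound 4; the limit leaves it open whether they differ This does not show that the gain is the same on the two cores, nor does it give the true size of either step, because compound 1 and compound 3 both start from a limit of the assay: the limit of > 20000 nM in this assay, at which 2 of the 4 values shown sit.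

The compounds shown leave open whether the gain belongs to 2-chlorophenyl as a whole or to the chlorine alone, since only two aryl groups appear and a plain phenyl, or a phenyl carrying fluorine or a methoxy group, would be needed to separate these readings. Also open, going by these compounds, is how far the change carries beyond these two cores, for instance to a core in which a simple amide replaces the link that holds the aryl group on its amine nitrogen.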